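This account rests on a few compounds, and the source may have more. Where it says the series, first, only, none or still open, it means among the compounds named here.

Measured in a functional assay on MDA-MB-231 cells (Homo sapiens) for inhibition, read by MTT assay, with a stated time of 72 h; a higher number here means a weaker inhibitor, a lower number a stronger inhibitor:

- Compound 1 `CC(C)[C@H](NC(=O)c1cc(Cl)ccc1OCCCCNC(=O)OC(C)(C)C)C(=O)Nc1ccc([N+](=O)[O-])cc1Cl`: > 10000 nM
- Compound 2 `CC(C)[C@H](NC(=O)c1cc(Cl)ccc1OC1CCN(C(=O)OC(C)(C)C)CC1)C(=O)Nc1ccc([N+](=O)[O-])cc1Cl`: > 10000 nM

Compound 2 gives > 10000 nM, which is a limit of the assay and not a number. The same holds for compound 1, so the data so far show (the limit of > 10000 nM in this assay, at which 2 of the 2 values shown sit). Neither measured compound gives a number to work from.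

Compound 3 `CC(C)[C@H](NC(=O)c1cc(Cl)ccc1OC1CCNCC1)C(=O)Nc1ccc([N+](=O)[O-])cc1Cl` differs from compound 2 in one place: hydrogen in place of tert-butoxycarbonyl on an amine nitrogen in a ring. This puts hydrogen in place of tert-butoxycarbonyl on an amine nitrogen in a ring.

For the measured compounds named here, no measured pair shows what this change does, so any forecast is loose. In this assay, a modest step towards stronger inhibition is expected, and a result that stays at the limit would be no surprise. The expected change is an at least 1.6-fold lower number from compound 2 to compound 3 (0.22 log units; that floor lies within the scatter). For compound 3 the estimated value is 6000 nM, with an expected range of 1500 nM to 20000 nM.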

Compound 3, half-maximal inhibitory concentration: 5230 nM
Compound 3: middle estimate off by 1.1-fold (0.06 log units), on the high side, within the range that was stated.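

In this assay, for the compounds shown here, compound 3 gives 5230 nM, the only value in this set that is a number and not a limit, so the core can give a readable result once the ring nitrogen carries hydrogen in place of tert-butoxycarbonyl. That change is an at least 1.9-fold lower number from compound 2 to compound 3 (0.28 log units; that floor lies within the scatter), and swapping the whole oxygen substituent, piperidin-4-yl in place of 4-((tert-butoxycarbonyl)amino)butyl, is an at least 1.9-fold lower number from compound 1 to compound 3 (0.28 log units; that floor lies within the scatter). On these data alone, each step is only a floor and its true size stays unknown, as both starting compounds sit at a limit: the limit of > 10000 nM in this assay, at which 2 of the 3 values shown sit.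

As far as these compounds go, it remains open whether the readable value belongs to the free ring amine or to the ring itself, and a butyl chain ending in a free primary amine would separate the two. Also open, from the compounds shown here alone, is how a methyl or an acetyl group on that ring nitrogen would read.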